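From dimethylamino to phenoxy: expecting little change

The source may report more compounds than this note shows. Statements on the series, on what has been measured and on what is new or still open speak of the compounds shown alone.

The values come from a functional assay on DU-145 cells (Homo sapiens) for inhibition, read by trypan blue exclusion, with a stated time of 96 h; a lower number here means a stronger inhibitor of growth, a higher number a weaker inhibitor of growth.
Compound 1 `Cc1ccc(S/C(=C/c2ccc(N(C)C)cc2)C(=O)c2ccc(Cl)cc2)cc1` gives > 100000 nM (a limit, not a number)
Compound 2 `Cc1ccc(S/C(=C/c2sccc2C)C(=O)c2ccc(Cl)cc2)cc1` gives 50000 nM
Compound 3 `Cc1ccc(S/C(=C/c2c(O)cc(O)cc2O)C(=O)c2ccc(Cl)cc2)cc1` gives > 100000 nM (a limit, not a number)

Compound 1 offers no number to start from: in this assay compound 1 gives > 100000 nM, which is a limit. That is the limit of > 100000 nM in this assay, at which 2 of the 3 values shown sit.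

Compound 4 `Cc1ccc(S/C(=C/c2ccc(Oc3ccccc3)cc2)C(=O)c2ccc(Cl)cc2)cc1` keeps the core of compound 1 and changes one group, with phenoxy in place of dimethylamino on an aromatic carbon, para to a large group: phenoxy in place of dimethylamino on an aromatic carbon.

Going by the values given here, no measured step makes this exact swap. Three steps instead replace the whole group that holds the dimethylamino. Putting 3-methylthiophen-2-yl there gave an at least 2.0-fold lower number from compound 1 to compound 2 (0.30 log units; that floor lies within the scatter). Putting 2,4,6-trihydroxyphenyl there gave a step that the two limits leave unreadable from compound 1 to compound 3. Moving between those two replacements gave an at least 2.0-fold higher number from compound 2 to compound 3 (0.30 log units; that floor lies within the scatter).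

Among the compounds with values here, none of these shows a size beyond the scatter, and compound 2, at 50000 nM, supplies the only real number to lean on. A small drop in the number, or none at all, is therefore expected, and a limit may be reported again. The estimated change is an at least 2.0-fold lower number from compound 1 to compound 4 (0.30 log units; that floor lies within the scatter). The estimate for compound 4 is 50000 nM, with an expected range from 15000 nM to 100000 nM.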

Compound 4, concentration for 50% growth inhibition: 10000 nM
Estimate against measurement, compound 4: 5.0-fold (0.70 log units) above; the whole stated range lies above it.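

Replacing dimethylamino with phenoxy on this aromatic carbon, para to a large group, gave an at least 10-fold lower number from compound 1 to compound 4 (1.00 log units; beyond the scatter) in this assay. This is the first step in the series that is shown to lie beyond the scatter, and it comes from changing one group while the rest of the core of compound 1 stays in place, whereas the earlier steps replaced the whole group that holds the dimethylamino. The size printed for it is only a floor, since compound 1 gives a limit and not a number: the limit of > 100000 nM in this assay, at which 2 of the 4 values shown sit.

The compounds shown cannot separate the possible sources of this step, as phenoxy adds a six-membered aromatic ring of carbon only and more heavy atoms, while the counts of hydrogen-bond donors and acceptors match those of dimethylamino. A methoxy group or a benzyl group on the same carbon would help to show whether the oxygen link, the added ring or simply the loss of the amine goes with the lower number.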